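Anilino to pyridinylamino on a glutarimide-bearing core

The source may report more compounds than this note shows. Statements on the series, on what has been measured and on what is new or still open speak of the compounds shown alone.

Measured compounds:
- Compound 1 `O=C1CCC(N2C(=O)c3ccc(Nc4ccccc4)cc3C2=O)C(=O)N1`: in an assay on FRT-Jurkat cells for inhibition of nuclear factor NF-kappa-B complex (Homo sapiens), read by flow cytometry, with a stated time of 24 h, tested at 10 uM (on this read-out higher numbers stand for more inhibition at the one concentration tested (going by the name of the read-out) and lower numbers for less inhibition), compound 1 gives 6%.
- Compound 2 `O=C1CCC(N2C(=O)c3cccc(Nc4ccccc4)c3C2=O)C(=O)N1`: in this assay compound 2 gives 4%.

Both numbers are small, and the gap between compound 2 and compound 1 lies within the usual scatter, so the two stand level, with little inhibition from either.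

Compound 3 `O=C1CCC(N2C(=O)c3cccc(Nc4ccccn4)c3C2=O)C(=O)N1` differs from compound 2 in one place: pyridin-2-yl in place of phenyl on a nitrogen on an aromatic ring. For the measured compounds named here, no measured pair shows the effect of such a change here, so no direction can be read from the data.

Compound 3 is expected to stay near compound 2, with a step of a number 1 percentage points higher from compound 2 to compound 3 (within the scatter) of no size beyond the scatter. The estimate for compound 3 in this assay is 5%, in the range -5% to 15%.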

Compound 3, a percentage reported as inhibition, at one concentration (the size of the read-out at that concentration, not a potency): 1%
Estimate against measurement, compound 3: 4 percentage points above, and the stated range covers the measured number.
By their numbers in this assay, from the lowest: compounds 3, 2 and 1 (each within the scatter of the next).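

Putting pyridin-2-yl in place of phenyl on a nitrogen on an aromatic ring gives a number 3 percentage points lower from compound 2 to compound 3 (within the scatter) in this assay. At this position, then, the hydrogen-bond acceptor that enters with pyridin-2-yl leaves the read-out level with that of the phenyl compound, and inhibition stays small. No measurement at hand gives a reason for this result.

From the compounds shown here alone, whether a carboxylic acid or a longer chain carrying an amine on that nitrogen would raise the inhibition stays open. So does whether pyridin-2-yl would behave alike on compound 1.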